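The source may report more compounds than this note shows. Statements on the series, on what has been measured and on what is new or still open speak of the compounds shown alone.

Of the compounds shown here, three built on one shared core have been measured. In a functional assay on HL-60 cells (Homo sapiens) for antiproliferative activity, with a stated time of 24 h (on this read-out lower numbers stand for stronger inhibition and higher numbers for weaker inhibition), compound 2 `NC(=O)c1c(NC(=O)c2ccccc2)sc2c1CCN(C(=S)Nc1ccccc1Cl)C2` gives 13800 nM, the lowest of the three numbers. Compound 3 `NC(=O)c1c(NC(=O)c2ccccc2F)sc2c1CCN(C(=O)Nc1ccccc1Cl)C2` gives 32700 nM and compound 1 `NC(=O)c1c(NC(=O)c2ccccc2Cl)sc2c1CCN(C(=S)Nc1cccnc1)C2` gives 33900 nM; both lie beyond the scatter from compound 2, yet each differs from it in more than one place, so no single step can be read from them. Compound 4 `NC(=O)c1c(NC(=O)c2ccc(C(F)(F)F)cc2)sc2c1CCN(C(=S)Nc1ccccc1Cl)C2` differs from compound 2 in one place only: trifluoromethyl in place of hydrogen on an aromatic carbon. Within the data shown here, no measured pair shows this change, so the expected step, a 1.1-fold higher number from compound 2 to compound 4 (0.04 log units; within the scatter), is small, of uncertain direction and likely within the scatter. Compound 4 is therefore estimated at 15000 nM in this assay, with a range from 5000 nM to 50000 nM.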

Compound 4, half-maximal inhibitory concentration: 36100 nM
The estimate for compound 4 lay 2.4-fold (0.38 log units) below the measured number; low and high end bracket the measured number.
By their numbers in this assay, from the lowest: compound 2; then compounds 3, 1 and 4 (each within the scatter of the next).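

In this assay, changing phenyl to 4-(trifluoromethyl)phenyl gives a 2.6-fold higher number from compound 2 to compound 4 (0.42 log units; beyond the scatter), a modest weakening that lies beyond the scatter. Among these compounds, this is the first single-place step in the set, and it shows that inhibition responds to what sits on this aromatic carbon, para to a large group. Nothing shown here explains why the number rises. Still open, going by these compounds, is how a methoxy group or an amine at this same place would compare with hydrogen and trifluoromethyl. On these data alone, whether the step would be the same with a different group elsewhere on the shared core also remains unknown.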